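The compounds below may be only part of what the source reports. "The series", "measured", "known", "first", "only" and "open" are said of these compounds alone.

The measured compounds:

compound 1, `Cc1nc(N)sc1CCCN/C(N)=N/C(=S)NC(c1ccccc1)c1ccccc1`, giving 603 nM
compound 2, `Cc1nc(N)sc1CCCN/C(N)=N/C(=O)NC(C)c1cccc(F)c1`, giving 2.04 nM
compound 3, `CCCCCNC(=O)/N=C(\N)NCCCc1sc(N)nc1C`, giving 4.47 nM

In an assay on membranes from Sf9 cells for displacement of a labelled ligand from histamine H2 receptor (Homo sapiens), read by scintillation counting, with a stated time of 60 min (a higher number here means a weaker inhibitor, a lower number a stronger inhibitor), compound 2 stands lowest of the three numbers. Compound 3 is the nearest to it, and that gap is beyond the usual scatter; compound 1 is the furthest away by a wide margin. The unmeasured compound 4, `Cc1nc(N)sc1CCCN/C(N)=N/C(=O)NC(C)c1ccc(Br)cc1`, differs from compound 2 in one place: 4-bromophenyl in place of 3-fluorophenyl on a saturated chain carbon bound to an amide-type nitrogen and a saturated chain carbon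

Among the measured compounds shown here, no measured pair shows what such a swap of one halogen-bearing aromatic ring for another does here, so the step is expected to be small, likely within the scatter, with a slight lean toward a higher number. Compound 4 is therefore estimated at 3.5 nM, in a range from 1.2 nM to 12 nM, which amounts to an expected step of a 1.7-fold higher number from compound 2 to compound 4 (0.23 log units; within the scatter).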

Compound 4, inhibition constant: 30.2 nM
Compound 4: the middle estimate sits 8.6-fold (0.94 log units) below what was measured; the whole stated range lies below it.
By their numbers in this assay, from the lowest: compound 2; then compound 3; then compound 4; then compound 1.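

At this position on the saturated chain carbon, the ring is far from interchangeable: in this assay, 4-bromophenyl in place of 3-fluorophenyl gives a 15-fold higher number from compound 2 to compound 4 (1.17 log units; beyond the scatter), although the heavy-atom count stays the same. This single swap changes both the halogen and its place on the ring. Nothing available here explains the size of this step.

Neither 3-bromophenyl nor 4-fluorophenyl is among the compounds shown. On these data alone, it therefore remains open whether the bromine or its ring place matters more.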